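From 2-chlorobenzyl to 3-bromobenzyl: working notes

The compounds below may be only part of what the source reports. "The series", "measured", "known", "first", "only" and "open" are said of these compounds alone.

Values in a functional assay on A-375 cells (Homo sapiens) for antiproliferative activity, read by MTT assay, with a stated time of 24 h; a higher number here means a weaker inhibitor, a lower number a stronger inhibitor:
- compound 1 `COc1cc(OC)c(-c2coc3cc(OCc4ccccc4C)ccc3c2=O)cc1OC`: 1360 nM
- compound 2 `COc1cc(OC)c(-c2coc3cc(OCc4ccccc4Cl)ccc3c2=O)cc1OC`: 2020 nM

Going by the values given here, only one measured step exists, chloro in place of methyl on an aromatic carbon: a 1.5-fold higher number from compound 1 to compound 2 (0.17 log units; within the scatter). Among the compounds with values here, compound 2 therefore stands level with the only other measured compound. The next change, to compound 3 `COc1cc(OC)c(-c2coc3cc(OCc4cccc(Br)c4)ccc3c2=O)cc1OC`, is 3-bromophenyl in place of 2-chlorophenyl on a saturated chain carbon bound to an oxygen on an aromatic ring. Within the data shown here, no measured compound carries 3-bromophenyl, so the single step is weak guidance. With compound 2 at 2020 nM as the anchor, no step beyond the scatter is expected in this assay. The expected change is a 1.1-fold lower number from compound 2 to compound 3 (0.05 log units; within the scatter). Compound 3 is estimated at 1800 nM, with an expected range of 700 nM to 4500 nM.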

Compound 3, half-maximal inhibitory concentration: 1120 nM
Compound 3: middle estimate off by 1.6-fold (0.21 log units), on the high side; the measured number falls inside the stated range.
By their numbers in this assay, from the lowest: compounds 3, 1 and 2 (each within the scatter of the next).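

In this assay, the change to 3-bromophenyl gives a 1.8-fold lower number from compound 2 to compound 3 (0.26 log units; within the scatter) and a 1.2-fold lower number from compound 1 to compound 3 (0.08 log units; within the scatter) in this series. Going by these compounds alone, this place therefore takes 3-bromophenyl as well as 2-chlorophenyl and 2-methylphenyl, with no step among the three compounds beyond the scatter. The halogen and its place on the ring change together in compound 3, so neither can be read alone.

From the compounds shown here alone, whether an amine, a carboxylic acid or a longer chain here would give a step beyond the scatter remains open. Nothing available bears on the cause of these small steps.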